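Notes on Fluoro Substitution and Cytotoxicity Limits

The source may report more compounds than this note shows. Statements on the series, on what has been measured and on what is new or still open speak of the compounds shown alone.

Of the compounds shown here, three of one shared core have been measured in a functional assay on NALM-6 cells (Homo sapiens) for cytotoxicity, with a stated time of 72 h; on this read-out higher numbers stand for an effect only at larger amounts of compound and lower numbers for an effect already at smaller amounts. Compound 1 `C=C[C@@](C)(/C=C/c1ccc(Nc2ccc(F)c(F)c2)cc1)CCC=C(C)C` carries a (3,4-difluorophenyl)amino group; in this assay compound 1 gives only a limit, > 43400 nM. Compound 2 `C=C[C@@](C)(/C=C/c1ccc(Nc2cc(F)c(F)cc2F)cc1)CCC=C(C)C` differs by fluoro in place of hydrogen on an aromatic carbon. In this assay compound 2 likewise gives only a limit, > 43400 nM. Compound 3 `C=C[C@@](C)(/C=C/c1ccc(-c2ccccc2)cc1)CCC=C(C)C` differs from compound 1 by phenyl in place of (3,4-difluorophenyl)amino on an aromatic carbon. In this assay compound 3 also gives only a limit, > 43400 nM. The steps a step that the two limits leave unreadable from compound 1 to compound 2 and a step that the two limits leave unreadable from compound 1 to compound 3 are thus not readable, since all three values sit at the limit of > 43400 nM in this assay, at which 3 of the 3 values shown sit.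

Compound 4 `C=C[C@@](C)(/C=C/c1ccc(-c2ccc(F)cc2)cc1)CCC=C(C)C` is not yet measured. It differs from compound 3 by fluoro in place of hydrogen on an aromatic carbon. This is the same kind of change as from compound 1 to compound 2, though the place differs: there the entering fluoro sits ortho to a large group, meta to a fluoro group and para to a fluoro group, whereas here it sits para to a large group. In this assay compound 4 is expected to give 50000 nM. The expected step that the limit leaves unreadable from compound 3 to compound 4 rests on a step that the two limits leave unreadable from compound 1 to compound 2 giving no readable size, so a limit is again the most likely outcome.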

Compound 4, half-maximal effective concentration: > 43400 nM
Compound 4: only a limit was reported; the forecaster's own chance of this, stated with the estimate: 85%; the middle value does not contradict the limit.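

In this assay compound 4 gives only a limit, > 43400 nM. No new step can be read from compound 3 or compound 1 to compound 4, since all values shown sit at one limit: the limit of > 43400 nM in this assay, at which 4 of the 4 values shown sit. The compounds shown leave open what size, if any, fluoro in place of hydrogen has in this assay.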